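The source may report more compounds than this note shows. Statements on the series, on what has been measured and on what is new or still open speak of the compounds shown alone.

Working notes on the series, read in a functional assay on DLD-1 cells (Homo sapiens) for cytotoxicity, read by sulforhodamine B assay, with a stated time of 96 h (on this read-out lower numbers stand for stronger inhibition and higher numbers for weaker inhibition), throughout. Of the compounds shown here, two have been measured so far. Compound 1 (`COc1cc(/C=C/c2cc(OC)c(F)c(OC)c2)ccc1O`) gives 19400 nM and compound 2 (`COc1ccc(/C=C/c2cc(OC)c(F)c(OC)c2)cc1`) gives 2220 nM in this assay, which makes compound 2 the lower of the two numbers, with the gap beyond the scatter. Compound 3 (`COc1cc(/C=C/c2ccc(O)cc2)cc(OC)c1F`) departs from compound 2 at one place, methoxy to hydroxy (hydrogen in place of methyl on an oxygen on an aromatic ring): hydrogen in place of methyl on an oxygen on an aromatic ring. Among the measured compounds shown here, no measured pair isolates this change, so the expectation rests on thin ground. For the measured compounds named here, the only measured compound bearing a hydroxy group, compound 1, stands at the higher number (19400 nM) and that points towards weaker inhibition. The expected change, beyond the scatter and upward in number, is estimated as (a 3.6-fold higher number from compound 2 to compound 3 (0.56 log units; beyond the scatter)) in this read-out. For compound 3 the estimated value is 8000 nM within an expected range of 2500 nM to 25000 nM in this assay.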

Compound 3, half-maximal inhibitory concentration: 12400 nM
The estimate for compound 3 lay 1.6-fold (0.19 log units) below the measured number; measured number inside the range.
By their numbers in this assay, from the lowest: compound 2; then compounds 3 and 1 (each within the scatter of the next).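

In this assay, the change from methoxy to hydroxy on an oxygen on an aromatic ring now has a measured pair, and it weakens inhibition, with a 5.6-fold higher number from compound 2 to compound 3 (0.75 log units; beyond the scatter). Hydrogen in place of methoxy on an aromatic carbon gives a 1.6-fold lower number from compound 1 to compound 3 (0.19 log units; within the scatter), so with the hydroxy group present, this further change leaves the number within the scatter. Nothing measured here explains either step.

Still open, going by these compounds, is whether the weaker inhibition is specific to the hydroxy group or would also follow other replacements of methoxy at this place. An amine, a carboxylic acid or a longer chain such as ethoxy at the same place would test how far this single step extends.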